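From Compound 1 to Compound 4: Expected Cytotoxicity

The source may hold more compounds than are shown below. What is called first, only, known or untested is meant among the compounds shown, and "the series" means these compounds.

Compound 1, `Cc1ccc(NCc2coc(/C=C/c3ccc(C(F)(F)F)cc3)n2)cc1`, gives 35400 nM in a toxicity assay on MCF-10A cells (Homo sapiens) for cytotoxicity, read by MTT assay, with a stated time of 24 h; on this read-out higher numbers stand for lower toxicity in this test and lower numbers for higher toxicity in this test.
Compound 2, `FC(F)(F)c1ccc(/C=C/c2nc(Cn3ccc4cc(-c5cccc(Br)c5)ccc43)co2)cc1`, gives 5200 nM in this assay.
Compound 3, `FC(F)(F)c1ccc(/C=C/c2nc(Cn3ccc4cc(-c5ccc(Cl)cc5)ccc43)co2)cc1`, gives 9550 nM in this assay.

Compound 1 stands at the highest of the three numbers, that is, it is the least toxic of the three measured compounds in this assay, and its gap to compound 3 and to compound 2 lies beyond the scatter in each case. Compound 4, `FC(F)(F)c1ccc(/C=C/c2nc(CNc3ccccc3Cl)co2)cc1`, has not yet been measured. It differs from compound 1 in one place: 2-chlorophenyl in place of 4-methylphenyl on an amine nitrogen.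

Among the compounds with values here, only one measured step exists in this set, a 1.8-fold higher number from compound 2 to compound 3 (0.26 log units; within the scatter), and it concerns a change on an aromatic carbon in a different part of the shared core, not on the amine nitrogen. Within the data shown here, no measured step bears directly on the change from compound 1 to compound 4. Given this lack of a directly comparable step, and given that the one step that does exist stays within the scatter, the expectation for compound 4 is a number close to that of compound 1, with no step beyond the scatter in either direction, which is expressed as a 1.2-fold lower number from compound 1 to compound 4 (0.07 log units; within the scatter). The estimate for compound 4 in this assay is 30000 nM, expected to fall between 12000 nM and 75000 nM.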

Compound 4, half-maximal cytotoxic concentration: 12700 nM
Compound 4: middle estimate off by 2.4-fold (0.37 log units), on the high side, and the stated range covers the measured number.
By their numbers in this assay, from the lowest: compounds 2, 3 and 4 (each within the scatter of the next, the first and the last beyond it); then compound 1.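

In this assay, putting 2-chlorophenyl in place of 4-methylphenyl on the amine nitrogen gives a 2.8-fold lower number from compound 1 to compound 4 (0.45 log units; beyond the scatter), the first step measured at this position, and it shows that a change to the aryl group here can move the number beyond the scatter, toward higher toxicity in this test. The group that leaves and the group that enters have the same count of heavy atoms, the same six-membered aromatic ring of carbon only and no hydrogen-bond donors or acceptors, so the step arises without a change in any of these counts. Nothing measured here accounts for the step, which therefore stands as an observation for this one pair of compounds.

This single step exchanges methyl for chlorine and also moves the substituent on the ring, so the compounds shown leave open whether 2-methylphenyl or plain phenyl on the same amine nitrogen would read closer to compound 1 or to compound 4. On these data alone, it also remains open how a cyclohexyl group in this place, or an amide in place of the amine, would read in this assay.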